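Swapping an amide for a benzyl amine on a weak binder

The compounds below may be only part of what the source reports. "The series", "measured", "known", "first", "only" and "open" are said of these compounds alone.

Compound 1 `O=C(c1nn(-c2ccccc2)c2c1CC(NCc1ccc(F)cc1)CC2)N1CCCCC1`: > 10000 nM
Compound 2 `CCCn1nc(C(=O)N(C)C)c2c1CCC(NC(=O)c1ccc(F)cc1)C2`: > 10000 nM

Both measurements come from an assay on isolated protein for antagonist activity at Sigma intracellular receptor 2 (Homo sapiens), read by scintillation counting, with a stated time of 120 min, in the presence of a further agent that is not named here; on this read-out lower numbers stand for stronger inhibition and higher numbers for weaker inhibition. For compound 2 the result is only a limit of the assay, > 10000 nM, not a number. For compound 1 the result is likewise only a limit, > 10000 nM. Compound 2 therefore stands at the limit of > 10000 nM in this assay, at which 2 of the 2 values shown sit, so nothing in the data places it above or below compound 1.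

Compound 3 `CCCn1nc(C(=O)N(C)C)c2c1CCC(NCc1ccc(F)cc1)C2` has not yet been measured in this assay. It differs from compound 2 in one place: 4-fluorobenzyl in place of (4-fluorophenyl)carbonyl on an amine nitrogen. Compound 1 also carries a 4-fluorobenzyl on an amine nitrogen, and compound 1 gives only a limit in this assay. Among the compounds with values here, with two limits and no measured step between them, a large change in either direction is not expected. Compound 3 is estimated at 8000 nM, within a range of 1500 nM to 30000 nM, which would mean an expected step of an at least 1.2-fold lower number from compound 2 to compound 3 (0.09 log units; that floor lies within the scatter).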

Compound 3, inhibition constant: 2000 nM
Compound 3: the middle estimate sits 4.0-fold (0.60 log units) above what was measured; the measured number falls inside the stated range.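

In this assay, the group on the amine nitrogen clearly matters: 4-fluorobenzyl in place of (4-fluorophenyl)carbonyl gives an at least 5.0-fold lower number from compound 2 to compound 3 (0.69 log units; beyond the scatter). Within the data shown here, compound 3 is the first compound here with a true number rather than a limit, so this position is one where a change can lift a compound into the range the assay can measure. As far as these compounds go, the step is only a minimum and the real gap remains unknown, since its starting point is a limit: the limit of > 10000 nM in this assay, at which 2 of the 3 values shown sit.

The compounds shown leave open whether the carbonyl itself is what holds compound 2 back, and whether a plain benzyl, without the fluorine, or a 2-phenylethyl group, with its longer chain, would give a lower or a higher number on the same amine nitrogen. They also leave open how a free primary amine, with no benzyl group on the nitrogen at all, would behave on the shared core.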